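The compounds below may be only part of what the source reports. "The series", "measured", "known", "first", "only" and "open" are said of these compounds alone.

Three thiazole amides from one series were measured in an ADME assay on HEK-293T cells (Homo sapiens) for inhibition, read by CCK-8 assay, with a stated time of 48 h, tested at 20 uM (on this read-out higher numbers stand for more inhibition of growth at the one concentration tested and lower numbers for less inhibition of growth), and a fourth is to follow. Compound 1 `COc1ccc(Cc2nnc(NC(=O)/C(C#N)=C/c3ccccc3OS(=O)(=O)c3ccccc3[N+](=O)[O-])s2)cc1` gives 18% in this assay. Compound 2 `COc1ccc(Cc2nnc(NC(=O)/C(C#N)=C/c3ccccc3OS(=O)(=O)c3ccc(Cl)cc3)s2)cc1` differs from compound 1 by 4-chlorophenyl in place of 2-nitrophenyl on a sulfonyl sulfur, and in this assay compound 2 gives 34%; that step is a number 16 percentage points higher from compound 1 to compound 2 (beyond the scatter). Compound 3 `N#C/C(=C\c1ccccc1OS(=O)(=O)c1ccccc1[N+](=O)[O-])C(=O)Nc1nnc(Cc2ccccc2)s1` differs from compound 1 by hydrogen in place of methoxy on an aromatic carbon, and in this assay compound 3 gives 10%; the step is a number 8 percentage points lower from compound 1 to compound 3 (within the scatter), so the values of compound 1 and compound 3 cannot be told apart on this read-out.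

Compound 4 `N#C/C(=C\c1ccccc1OS(=O)(=O)c1ccc(Cl)cc1)C(=O)Nc1nnc(Cc2ccccc2)s1` has not yet been measured. It differs from compound 3 by 4-chlorophenyl in place of 2-nitrophenyl on a sulfonyl sulfur. This is the same change that was made from compound 1 to compound 2, at the same place, on a sulfonyl sulfur whose other neighbour is an oxygen on an aromatic ring; the two cores differ only by hydrogen in place of methoxy on an aromatic carbon. Among the measured compounds shown here, because a number 16 percentage points higher from compound 1 to compound 2 (beyond the scatter) was seen for the one measured pair, a step of similar size is expected for compound 4, though it rests on a single pair and on a core whose value sits within the scatter of compound 1. The expected step is a number 16 percentage points higher from compound 3 to compound 4 (beyond the scatter). Compound 4 is therefore estimated at 26% in this assay, with a range from 12% to 40%.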

Compound 4, percent growth inhibition at one concentration: 25%
Estimate against measurement, compound 4: 1 percentage points above; measured number inside the range.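

In this assay, 4-chlorophenyl in place of 2-nitrophenyl on a sulfonyl sulfur gave a number 15 percentage points higher from compound 3 to compound 4 (beyond the scatter), and the change carried over from the core of compound 1 to the core of compound 3 with no difference that can be told apart: the same change on two cores in this assay, a number 16 percentage points higher (beyond the scatter) from compound 1 to compound 2 and a number 15 percentage points higher (beyond the scatter) from compound 3 to compound 4, 1 percentage points apart, within the scatter of two such steps. Hydrogen in place of methoxy on an aromatic carbon, read this time with the 4-chlorophenyl group in place, gave a number 9 percentage points lower from compound 2 to compound 4 (within the scatter), so that change remains unresolved with either sulfonyl group, and the two readings agree: the same change on two cores in this assay, a number 8 percentage points lower (within the scatter) from compound 1 to compound 3 and a number 9 percentage points lower (within the scatter) from compound 2 to compound 4, 1 percentage points apart, within the scatter of two such steps. These four compounds form one small set of two cores and two sulfonyl groups, so they show that the change transfers between these two closely related cores, but not that it would transfer to any other core in the series, nor why it raises the number.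

The compounds shown leave open whether the step comes from losing the nitro group, from gaining the chlorine, or from both, and whether a plain phenyl or a methyl on the sulfonyl sulfur would fall in line with it. Also open, from the compounds shown here alone, is whether an amine or a carboxylic acid in place of the methoxy would move the number beyond the scatter with either sulfonyl group.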